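Moving an acetoxy group on an arylated rhodanine-type nitrogen

A few compounds are considered here, and "the series" means these few. Any claim that something is new, unique, unknown or untested is made for them only; others in the source may bear on it.

Compound 2 `CC(=O)Oc1ccc(N2C(=O)/C(=C/N3N=C(c4ccccc4)CC3c3ccccc3O)SC2=S)cc1` and compound 1 `CC(=O)Oc1cccc(N2C(=O)/C(=C/N3N=C(c4ccccc4)CC3c3ccccc3O)SC2=S)c1` share one core and differ only in 3-acetoxyphenyl in place of 4-acetoxyphenyl on an amide-type nitrogen in a ring. In a functional assay on HL-60 cells (Homo sapiens) for antiproliferative activity, read by MTT assay, with a stated time of 72 h (a lower number here means a stronger inhibitor, a higher number a weaker inhibitor), compound 2 gives 9400 nM, whereas compound 1 gives 118 nM, so the change produced an 80-fold lower number from compound 2 to compound 1 (1.90 log units; beyond the scatter). Compound 3 `CC(=O)Oc1ccc(N2C(=O)/C(=C/N3N=C(c4ccc5ccccc5c4)CC3c3ccc(Cl)cc3)SC2=S)cc1` carries a different core; how that core differs from the core of compound 2 is not broken down here. In this assay compound 3 gives 1800 nM, which stands between the values of compound 1 and compound 2. Compound 4 `CC(=O)Oc1cccc(N2C(=O)/C(=C/N3N=C(c4ccc5ccccc5c4)CC3c3ccc(Cl)cc3)SC2=S)c1` relates to compound 3 exactly as compound 1 relates to compound 2: 3-acetoxyphenyl in place of 4-acetoxyphenyl on an amide-type nitrogen in a ring. The place of the change is the same in both pairs, so this is the same change, seen twice among these compounds. Because the step from compound 2 to compound 1 was an 80-fold lower number from compound 2 to compound 1 (1.90 log units; beyond the scatter), a step in the same direction is expected from compound 3 to compound 4, though with a different core the size is uncertain and is estimated as an 18-fold lower number from compound 3 to compound 4 (1.26 log units; beyond the scatter). Compound 4 is therefore expected to give about 100 nM in this assay, with a likely range from 20 nM to 500 nM.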

Compound 4, half-maximal inhibitory concentration: 1020 nM
Estimate against measurement, compound 4: 10-fold (1.01 log units) below; measured number outside the range, above it.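

On the core of compound 4, the shift from 4-acetoxyphenyl to 3-acetoxyphenyl in this assay gives a 1.8-fold lower number from compound 3 to compound 4 (0.25 log units; within the scatter), so here the change has no effect that can be told from the scatter. The large step seen on the first core therefore does not carry over in size, and the two cores give clearly different results: the same change on two cores in this assay, an 80-fold lower number (1.90 log units; beyond the scatter) from compound 2 to compound 1 and a 1.8-fold lower number (0.25 log units; within the scatter) from compound 3 to compound 4, 45-fold (1.65 log units) apart, beyond the scatter of two such steps

This shows that the effect of the change depends on the core, but it does not show which part of the core is responsible, since the two cores differ in more than one place.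

With only two cores shown, it remains open how the change would behave on a core that differs from the core of compound 1 in just one of those places. As far as these compounds go, it also remains open what a free hydroxyl, an amine or a carboxylic acid in place of the acetoxy group would do on either core.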